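Chalcone amides: cytotoxicity on Vero cells, compound 4 expected

This account rests on a few compounds, and the source may have more. Where it says the series, first, only, none or still open, it means among the compounds named here.

Measured so far in an ADME assay on Vero cells (Chlorocebus sabaeus) for cytotoxicity, read by MTT assay, with a stated time of 72 h; on this read-out lower numbers stand for higher toxicity in this test and higher numbers for lower toxicity in this test:
Compound 1 `COC(=O)c1cc(-c2cccc(NC(=O)c3ccc(/C=C/C(=O)c4ccc(F)cc4F)cc3)c2)on1`: > 40 ug/mL, a limit of the assay.
Compound 2 `COC(=O)c1cc(-c2cccc(NC(=O)c3ccc(/C=C/C(=O)c4ccccc4O)cc3)c2)on1`: "not determined" (no result reported).
Compound 3 `CCCOc1ccc(C(=O)/C=C/c2ccc(C(=O)Nc3cccc(-c4cc(C(=O)OC)no4)c3)cc2)cc1`: > 40 ug/mL, a limit of the assay.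

Compound 3 stands only at a limit in this assay; no single number for it is known. Of the three entries shown, two sit at the same limit of > 40 ug/mL in this assay, at which 2 of the 3 values shown sit, and the third carries no result. Among the measured compounds shown here, the one measured step that touches compound 3 is a step that the two limits leave unreadable from compound 1 to compound 3, and as both ends are limits its size cannot be read.

Compound 4 `COC(=O)c1cc(-c2cccc(NC(=O)c3ccc(/C=C/C(=O)c4ccc(OC)c(OC)c4)cc3)c2)on1` differs from compound 3 in one place: 3,4-dimethoxyphenyl in place of 4-propoxyphenyl on a carbonyl carbon

For the measured compounds named here, no measured step bears on this change directly. Going by the values given here, the only comparable step, a step that the two limits leave unreadable from compound 1 to compound 3, is unreadable, and there is no measured value from which a direction could be taken. The expectation for compound 4 therefore rests on the two compounds that sit at the limit (the limit of > 40 ug/mL in this assay, at which 2 of the 3 values shown sit), and the step that the limit leaves unreadable from compound 3 to compound 4 is expected to stay within the scatter. Compound 4 is estimated at 60 ug/mL, with a range from 25 ug/mL to 150 ug/mL, and most likely the assay again reports only a limit.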

Compound 4, half-maximal cytotoxic concentration: > 50 ug/mL
Compound 4: a limit, no number; the forecaster's own chance of this, stated with the estimate: 70%; the middle value does not contradict the limit.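

Among the compounds shown here, compound 1, compound 3 and compound 4 all stand only at limits in this assay, so no step among them can be read. The compounds shown leave open how far each half-maximal cytotoxic concentration lies past its limit, and whether 2,4-difluorophenyl, 4-propoxyphenyl and 3,4-dimethoxyphenyl on a carbonyl carbon differ at all in this assay.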